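This account rests on a few compounds, and the source may have more. Where it says the series, first, only, none or still open, it means among the compounds named here.

Compound 1 `C/C(=C\CC/C(C)=C/CC[C@@H]1[C@@]2(C)CCC(=O)C(C)(C)[C@H]2CC[C@@]1(C)O)CC/C=C(\C)C(=O)OCc1cn(-c2cccc(C)c2)nn1` carries a 1-(3-methylphenyl)-1H-1,2,3-triazol-4-yl group on the shared core. In an ADME assay on L132 cells (Homo sapiens) for cytotoxicity, read by MTT assay, with a stated time of 48 h (a lower number here means a stronger inhibitor, a higher number a weaker inhibitor), compound 1 gives only a limit of the assay, > 150000 nM. Compound 3 `C/C(=C\CC/C(C)=C/CC[C@@H]1[C@@]2(C)CCC(=O)C(C)(C)[C@H]2CC[C@@]1(C)O)CC/C=C(\C)C(=O)OCc1cn(-c2ccc(Cl)cc2)nn1` likewise gives only a limit, > 150000 nM. The step that the two limits leave unreadable from compound 1 to compound 3 therefore cannot be sized. Compound 2 `C/C(=C\CC/C(C)=C/CC[C@@H]1[C@@]2(C)CCC(=O)C(C)(C)[C@H]2CC[C@@]1(C)O)CC/C=C(\C)C(=O)OCc1cn([C@@H]2C[C@@H](n3cc(C)c(=O)[nH]c3=O)O[C@H]2CO)nn1` gives a number, 115000 nM, close to the limit of > 150000 nM in this assay, at which 2 of the 3 values shown sit. Compound 4 `C/C(=C\CC/C(C)=C/CC[C@@H]1[C@@]2(C)CCC(=O)C(C)(C)[C@H]2CC[C@@]1(C)O)CC/C=C(\C)C(=O)OCc1cn(-c2cccc(O)c2)nn1` differs from compound 1 by hydroxy in place of methyl on an aromatic carbon. No measured step involves this change, and the single step shown has no readable size, so no direction can be drawn from it. Compound 1 stands at the limit > 150000 nM. Compound 4 is therefore expected to show a number no higher from compound 1 to compound 4 (the limit leaves the size open). Compound 4 is estimated at 150000 nM, with a range from 90000 nM to 300000 nM.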

Compound 4, half-maximal inhibitory concentration: 146000 nM
Compound 4: middle estimate off by 1.0-fold (0.01 log units), on the high side, and the stated range covers the measured number.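

Unlike compound 1 and compound 3, compound 4 gives a real number in this assay, 146000 nM, so a phenyl group carrying hydroxy can be read in this assay. Hydroxy in place of methyl gives an at least 1.0-fold lower number from compound 1 to compound 4 (0.01 log units; that floor lies within the scatter), and the change from 4-chlorophenyl to 3-hydroxyphenyl gives an at least 1.0-fold lower number from compound 3 to compound 4 (0.01 log units; that floor lies within the scatter). The true size of both steps stays unknown, as each starts from a limit and not a number: the limit of > 150000 nM in this assay, at which 2 of the 4 values shown sit.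

Going by these compounds, whether an amine or a carboxylic acid on this ring would bring the number clearly lower remains open.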